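Notes on the step from compound 1 to compound 3

A few compounds are considered here, and "the series" means these few. Any claim that something is new, unique, unknown or untested is made for them only; others in the source may bear on it.

Compound 1 `Clc1cccc2c1CC2CCCN1CCN(c2cccc3c2OCCO3)CC1` has the highest number of the two measured values in a functional assay on the whole organism for antagonist activity, with Rattus norvegicus as the target (a lower number here means that less compound is needed, a higher number that more compound is needed for the effect), giving 3.09 mg/kg. Compound 2 `COc1ccc2c(c1)C(CCN1CCN(c3cccc4c3OCCO4)CC1)C2` gives 0.48 mg/kg in this assay, a gap beyond the scatter. Compound 3 `c1ccc2c(c1)CCC2CCCN1CCN(c2cccc3c2OCCO3)CC1` differs from compound 1 by a group of 9 heavy atoms (9 carbon; one five-membered non-aromatic ring of carbon only, one six-membered aromatic ring of carbon only) in place of a group of 9 heavy atoms (8 carbon, 1 chlorine; one four-membered non-aromatic ring of carbon only, one six-membered aromatic ring of carbon only), on a saturated chain carbon, three bonds along the chain from an amine nitrogen in a ring. Going by the values given here, no measured pair shows this change, so the direction is uncertain; a moderate decrease in the number is expected, not a large one. For compound 3 the estimated step of a 2.1-fold lower number from compound 1 to compound 3 (0.31 log units; beyond the scatter) is moderate, and its value in this assay is expected near 1.5 mg/kg, within 0.5 mg/kg to 5 mg/kg.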

Compound 3, dose for 50% inhibition: 0.29 mg/kg
Estimate against measurement, compound 3: 5.2-fold (0.71 log units) above; the whole stated range lies above it.
By their numbers in this assay, from the lowest: compounds 3 and 2 (each within the scatter of the next); then compound 1.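

The earlier compounds shown here gave no step at this position. On the saturated chain carbon, three bonds along the chain from an amine nitrogen in a ring, the 2,3-dihydro-1H-inden-1-yl group in place of the chlorine-bearing group with the four-membered ring gives an 11-fold lower number from compound 1 to compound 3 (1.03 log units; beyond the scatter) in this assay, a large change. Nothing available accounts for the size of this step.

The step changes ring size and removes chlorine together, leaving their separate contributions open. Also open, on these data alone, is how a longer chain or a fluorine on the 2,3-dihydro-1H-inden-1-yl group would read.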